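The source may hold more compounds than are shown below. What is called first, only, known or untested is meant among the compounds shown, and "the series" means these compounds.

Measured in a functional assay on RS4-11 cells (Homo sapiens) for inhibition, read by CCK-8 assay, with a stated time of 48 h; a lower number here means a stronger inhibitor, a higher number a weaker inhibitor:
Compound 1 `O=[N+]([O-])c1ccc(NC(=S)NCCNS(=O)(=O)c2ccc(-c3ccccc3O[C@H]3CC[C@@H](O)CC3)s2)cc1` — 9400 nM.
Compound 2 `O=S(=O)(NCCNC(=S)Nc1cc(C(F)(F)F)cc(C(F)(F)F)c1)c1ccc(-c2ccccc2OCc2ccccc2)s1` — > 50000 nM, which is a limit of the assay and not a number.
Compound 3 `O=[N+]([O-])c1ccc(Oc2ccccc2-c2ccc(S(=O)(=O)NCCNC(=S)Nc3cc(C(F)(F)F)cc(C(F)(F)F)c3)s2)cc1` — 6300 nM.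

Compound 3 gives the lowest of the two numbers, but compound 1 sits within the scatter of it, so no order between the two can be claimed. Compound 2 stands at the limit (the limit of > 50000 nM in this assay, at which 1 of the 3 values shown sits).

For the measured compounds named here, the one measured step on this part of the structure is an at least 7.9-fold lower number from compound 2 to compound 3 (0.89 log units; beyond the scatter). Compound 4 `O=S(=O)(NCCNC(=S)Nc1cc(C(F)(F)F)cc(C(F)(F)F)c1)c1ccc(-c2ccccc2Oc2ccc(O)c(O)c2)s1` continues from compound 3 with 3,4-dihydroxyphenyl in place of 4-nitrophenyl on an oxygen on an aromatic ring. Going by the values given here, the change sits on the same oxygen as the measured step, yet nothing measured bears on a 3,4-dihydroxyphenyl at this place; the step from compound 2 to compound 3 shows only that the group on this oxygen can move the number beyond the scatter. In this assay the expected step is a 1.6-fold higher number from compound 3 to compound 4 (0.20 log units; within the scatter), a modest weakening at most, with wide uncertainty in both directions. Compound 4 is estimated at 10000 nM, between 3000 nM and 40000 nM.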

Compound 4, half-maximal inhibitory concentration: 10300 nM
Compound 4: the middle estimate sits 1.0-fold (0.01 log units) below what was measured, within the range that was stated.
By their numbers in this assay, from the lowest: compounds 3, 1 and 4 (each within the scatter of the next). At a limit, above all of these: compound 2.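

In this assay, exchanging 4-nitrophenyl for 3,4-dihydroxyphenyl on this oxygen leaves the number within the scatter: a 1.6-fold higher number from compound 3 to compound 4 (0.21 log units; within the scatter). The 4-nitrophenyl is therefore not needed to hold the value of compound 3, and a second group attached directly through this oxygen also stands clear of benzyl: an at least 4.8-fold lower number from compound 2 to compound 4 (0.68 log units; beyond the scatter). Compound 2 gives a limit and not a number: the limit of > 50000 nM in this assay, at which 1 of the 4 values shown sits.

Going by these compounds, whether an unsubstituted phenyl, a 4-aminophenyl or a 4-carboxyphenyl on this oxygen would stay in the same range remains open, as does whether either hydroxyl of the 3,4-dihydroxyphenyl alone would suffice. Also open, on these data alone, is whether the step from 4-nitrophenyl to 3,4-dihydroxyphenyl holds when the other end of the molecule is that of compound 1.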